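A few compounds are considered here, and "the series" means these few. Any claim that something is new, unique, unknown or untested is made for them only; others in the source may bear on it.

Measured so far in a functional assay on microsomes for inhibition, with a stated time of 1 h; on this read-out lower numbers stand for stronger inhibition and higher numbers for weaker inhibition:
- Compound 1 `COc1ccc(-c2nc(NN)n(C)c(=O)c2C#N)cc1`: 39 ug/mL
- Compound 2 `CN(C)c1ccc(-c2nc(NN)n(C)c(=O)c2C#N)cc1`: 63 ug/mL

Within the data shown here, compound 2 lies within the scatter of compound 1, the only other compound measured, so these two values cannot be told apart. Compound 3 `Cn1c(NN)nc(-c2ccc(Cl)cc2)c(C#N)c1=O` has not been measured yet. It differs from compound 2 in one place, with chloro in place of dimethylamino on an aromatic carbon, para to a large group (chloro in place of dimethylamino on an aromatic carbon). Among the measured compounds shown here, only one measured step bears on this change, as it also involves dimethylamino on an aromatic carbon: a 1.6-fold higher number from compound 1 to compound 2 (0.21 log units; within the scatter). For the measured compounds named here, no measured compound carries chloro, so this single step is only a weak guide. It gives no reason to expect a change beyond the scatter, and it points to no firm direction. The estimated step is a 1.4-fold lower number from compound 2 to compound 3 (0.15 log units; within the scatter). In this assay, compound 3 is expected at 45 ug/mL, with an estimated range from 18 ug/mL to 110 ug/mL.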

Compound 3, half-maximal inhibitory concentration: 46 ug/mL
For compound 3 the middle estimate is 1.0-fold (0.01 log units) below the measured one, and the stated range covers the measured number.
By their numbers in this assay, from the lowest: compounds 1, 3 and 2 (each within the scatter of the next).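

Measured in this assay the replacement of dimethylamino, with its 3 heavy atoms and 1 hydrogen-bond acceptor, by chloro, with 1 heavy atom and 0 hydrogen-bond acceptors, gives a 1.4-fold lower number from compound 2 to compound 3 (0.14 log units; within the scatter) so this larger difference in the group's atom count leaves the two numbers indistinguishable. Chloro in place of methoxy gives a 1.2-fold higher number from compound 1 to compound 3 (0.07 log units; within the scatter) and thus all three groups at this place on the aromatic ring, para to a large group, give numbers that cannot be told apart. Nothing available explains why these different groups read alike.

As far as these compounds go, whether a carboxylic acid, a primary amine or a longer alkyl chain at this place would move the number beyond the scatter remains open. From the compounds shown here alone, all three compounds share the same core, so the effect of changes elsewhere on it also remains unknown.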